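Aryl sulfonamides: cytotoxicity notes ahead of compound 4

The compounds below may be only part of what the source reports. "The series", "measured", "known", "first", "only" and "open" are said of these compounds alone.

Measured so far:
Compound 1 `COc1ccccc1-c1cccc(S(=O)(=O)N2CCC(N3CCC(C)CC3)CC2)c1`: in an ADME assay on HCT-116 cells (Homo sapiens) for cytotoxicity, read by CellTiter-Glo, with a stated time of 72 h (a higher number here means a weaker inhibitor, a lower number a stronger inhibitor), compound 1 gives > 5000 nM, a limit of the assay.
Compound 2 `Cc1noc(C)c1S(=O)(=O)N1CCC(N2CCC(C)CC2)CC1`: in this assay compound 2 gives > 10000 nM, also a limit.
Compound 3 `CC1CCN(C2CCN(S(=O)(=O)c3ccc(F)cc3F)CC2)CC1`: in this assay compound 3 gives > 5000 nM, again a limit.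

Going by the values given here, every value so far is a limit. Compound 1 sits at the limit of > 5000 nM in this assay, at which 2 of the 3 values shown sit, and no number separates it from the other two. Among the compounds with values here, the one single-point step, a step that the two limits leave unreadable from compound 2 to compound 3, has limits at both ends and yields no size. Compound 4 `Cc1ccc(-c2cccc(S(=O)(=O)N3CCC(N4CCC(C)CC4)CC3)c2)cc1` carries 4-methylphenyl in place of 2-methoxyphenyl on an aromatic carbon. Within the data shown here, no measured step touches that change, and the readings on the shared core, the limit of > 10000 nM in this assay, at which 1 of the 3 values shown sits, and (the limit of > 5000 nM in this assay, at which 2 of the 3 values shown sit), give no foothold for a direction. The step that the limit leaves unreadable from compound 1 to compound 4 is therefore expected to fall within the scatter. Compound 4 is estimated at 8000 nM, within 3000 nM to 25000 nM, most likely reported again as a limit.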

Compound 4, half-maximal inhibitory concentration: > 5000 nM
Compound 4 was reported as a limit (the forecaster's own chance of this, stated with the estimate: 85%); the middle value is on the limit's open side.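

Compound 1 and compound 4 both stand as limits in this assay, and the step between them cannot be read. The compounds shown leave open whether any member of this series reaches a measurable half-maximal inhibitory concentration in this assay.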